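Swapping the benzyl substituent on a pyrazolylamino-quinazoline core

The compounds below may be only part of what the source reports. "The series", "measured", "known", "first", "only" and "open" are said of these compounds alone.

Compound 1 `Cc1cc(Nc2nc(NCc3ccc(C#N)cc3)nc3ccccc23)n[nH]1`: 83 nM
Compound 2 `Cc1cc(Nc2nc(NCc3ccc(C(F)(F)F)cc3)nc3ccccc23)n[nH]1`: 1400 nM

In an assay for inhibition of high affinity nerve growth factor receptor (Homo sapiens), read by HTRF, with a stated time of 30 min, in the presence of a further agent that is not named here (on this read-out higher numbers stand for weaker inhibition and lower numbers for stronger inhibition), compound 1 gives 83 nM, the lowest of the two numbers, while compound 2 gives 1400 nM. Within the data shown here, the single measured step, a 17-fold higher number from compound 1 to compound 2 (1.23 log units; beyond the scatter), shows that exchanging the cyano group costs much. Compound 3 `Cc1cc(Nc2nc(NCc3cc(F)ccc3F)nc3ccccc23)n[nH]1` carries the change (2,5-difluorophenyl in place of 4-cyanophenyl on a saturated chain carbon bound to a nitrogen on an aromatic ring); the cyano acceptor leaves here too, so that step bears on it, though the entering group differs. Compound 3 is therefore expected to give a higher number, a 6.0-fold higher number from compound 1 to compound 3 (0.78 log units; beyond the scatter), estimated at 500 nM within a range of 150 nM to 2000 nM.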

Compound 3, half-maximal inhibitory concentration: 7.5 nM
Estimate against measurement, compound 3: 67-fold (1.82 log units) above, and the stated range ends above it.
By their numbers in this assay, from the lowest: compound 3; then compound 1; then compound 2.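

In this assay, replacing 4-cyanophenyl with 2,5-difluorophenyl on a saturated chain carbon bound to a nitrogen on an aromatic ring gives an 11-fold lower number from compound 1 to compound 3 (1.04 log units; beyond the scatter). Removing the cyano group therefore does not in itself weaken inhibition at this position, and the nitrile is not required, since the entering group has no hydrogen-bond acceptor. No available evidence accounts for this gain.

The compounds shown leave open whether a single fluorine would be enough, since both enter together. As far as these compounds go, it also remains open how a methoxy group or an amine on this ring would read.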